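A few compounds are considered here, and "the series" means these few. Any claim that something is new, unique, unknown or untested is made for them only; others in the source may bear on it.

Measured compounds: compound 1 `CC(C)(C)N(NC(=O)c1ccccc1)C(=O)c1ccccc1Cl` gives 75.9 nM in an assay on cells for agonist activity at ecdysone receptor (Bombyx mori), read by a luciferase reporter, with a stated time of 24 h; on this read-out lower numbers stand for an effect already at smaller amounts and higher numbers for an effect only at larger amounts of compound; compound 2 `CC(C)(C)N(NC(=O)c1ccccc1F)C(=O)c1ccccc1Cl` gives 51.3 nM; compound 3 `CC(C)(C)N(NC(=O)c1ccc(F)cc1)C(=O)c1ccccc1Cl` gives 389 nM.

Compound 3 stands highest of these three. The gaps to it are clear: a 5.1-fold higher number from compound 1 to compound 3 (0.71 log units; beyond the scatter) and a 7.6-fold higher number from compound 2 to compound 3 (0.88 log units; beyond the scatter), so the para fluoro of compound 3 is tied to a weaker effect than the unsubstituted or 2-fluoro ring.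

Compound 4 `CC(C)(C)N(NC(=O)c1ccc(Br)cc1)C(=O)c1ccccc1Cl` differs from compound 3 by bromo in place of fluoro on an aromatic carbon. Among the compounds with values here, no measured step exchanges one halogen for another, so the measured steps only show that this para position is sensitive. With nothing to set the direction, compound 4 is estimated to sit close to compound 3, a step of a 1.3-fold lower number from compound 3 to compound 4 (0.11 log units; within the scatter), giving an expected 300 nM with a range of 70 nM to 1500 nM.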

Compound 4, half-maximal effective concentration: 33.9 nM
Estimate against measurement, compound 4: 8.8-fold (0.95 log units) above; measured number outside the range, below it.
By their numbers in this assay, from the lowest: compounds 4, 2 and 1 (each within the scatter of the next, the first and the last beyond it); then compound 3.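

At this position the kind of halogen decides the outcome, not merely whether one is present: with bromo in place of fluoro there is an 11-fold lower number from compound 3 to compound 4 (1.06 log units; beyond the scatter). Bromo even improves on plain hydrogen, with a 2.2-fold lower number from compound 1 to compound 4 (0.35 log units; beyond the scatter), while a 1.5-fold lower number from compound 2 to compound 4 (0.18 log units; within the scatter) stays within the scatter, so the 4-bromophenyl and 2-fluorophenyl compounds cannot be told apart. Nothing available explains why the two halogens differ so sharply. As far as these compounds go, it remains open whether chloro at this position would behave more like fluoro or like bromo. An amine or a methoxy group there is equally uncharted.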